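This account rests on a few compounds, and the source may have more. Where it says the series, first, only, none or still open, it means among the compounds named here.

Series in a functional assay on A549 cells (Homo sapiens) for cytotoxicity, read by MTT assay, with a stated time of 68 h; on this read-out lower numbers stand for stronger inhibition and higher numbers for weaker inhibition:
- compound 1 `COc1ccc(-c2cccc(NC(=O)C(Cl)Cl)c2)cc1`: 8530 nM
- compound 2 `O=C(Nc1cccc(-c2ccc(F)cc2)c1)C(Cl)Cl`: 7840 nM
- compound 3 `O=C(Nc1cccc(-c2ccc(C(F)(F)F)cc2)c1)C(Cl)Cl`: not yet measured

Compound 2, at 7840 nM, cannot be separated from compound 1 on these numbers. The next change is trifluoromethyl in place of fluoro on an aromatic carbon. Among the measured compounds shown here, only one measured step bears on it, also a swap of a group on an aromatic carbon: a 1.1-fold lower number from compound 1 to compound 2 (0.04 log units; within the scatter). No shift beyond the scatter is therefore expected in this assay. The estimated step is a 1.1-fold lower number from compound 2 to compound 3 (0.05 log units; within the scatter). Compound 3 is expected at 7000 nM, with an estimated range of 3200 nM to 14000 nM.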

Compound 3, half-maximal inhibitory concentration: 23500 nM
The estimate for compound 3 lay 3.4-fold (0.53 log units) below the measured number, and the stated range ends below it.
By their numbers in this assay, from the lowest: compounds 2 and 1 (each within the scatter of the next); then compound 3.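

In this assay the group at this place on the aromatic ring does matter: trifluoromethyl in place of fluoro gives a 3.0-fold higher number from compound 2 to compound 3 (0.48 log units; beyond the scatter) and trifluoromethyl in place of methoxy gives a 2.8-fold higher number from compound 1 to compound 3 (0.44 log units; beyond the scatter) while fluoro in place of methoxy stayed within the scatter. Both new steps are modest, and they set compound 3 apart from compound 1 and compound 2. Nothing available accounts for this shift.

As far as these compounds go, whether the shift is particular to trifluoromethyl remains open. A methyl, a chloro or an amine at this place would help to decide that.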